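The source may hold more compounds than are shown below. What is called first, only, known or untested is meant among the compounds shown, and "the series" means these compounds.

Compound 3 `N#CC1CN1C(=O)Nc1ccccc1` is measured in a functional assay on WiDr cells (Homo sapiens) for inhibition (on this read-out higher numbers stand for weaker inhibition and lower numbers for stronger inhibition), at 5000 nM. Two close relatives sit with it inside the usual scatter: compound 2 `N#CC1CN1C(=O)Nc1ccc([N+](=O)[O-])cc1` gives 4300 nM in this assay, and the step of a 1.2-fold higher number from compound 2 to compound 3 (0.07 log units; within the scatter) is small; compound 1 `CCOC(=O)c1ccc(NC(=O)N2CC2C#N)cc1` gives 2500 nM in this assay, and the step of a 2.0-fold higher number from compound 1 to compound 3 (0.30 log units; within the scatter) is likewise small. Compound 4 `N#CC1CN1C(=O)Nc1ccc(C(F)(F)F)cc1` changes compound 3 in one place: trifluoromethyl in place of hydrogen on an aromatic carbon. The two steps that bear on this, from compound 1 and from compound 2 to compound 3, both swap a group at that same place against hydrogen and both stay within the scatter. In this assay compound 4 is therefore expected to show a change of a 1.4-fold lower number from compound 3 to compound 4 (0.15 log units; within the scatter), no more than the scatter. The estimate for compound 4 is 3500 nM, in a range from 1500 nM to 8000 nM.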

Compound 4, half-maximal inhibitory concentration: 1300 nM
Compound 4: middle estimate off by 2.7-fold (0.43 log units), on the high side, and the stated range ends above it.
By their numbers in this assay, from the lowest: compounds 4, 1, 2 and 3 (each within the scatter of the next, the first and the last beyond it).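

In this assay this position now shows steps beyond the scatter: a 3.8-fold lower number from compound 3 to compound 4 (0.59 log units; beyond the scatter) with trifluoromethyl in place of hydrogen and a 3.3-fold lower number from compound 2 to compound 4 (0.52 log units; beyond the scatter) with trifluoromethyl in place of nitro. The earlier swaps at this place all stayed within the scatter, so the choice of group here can matter. Trifluoromethyl and ethoxycarbonyl remain unseparated, since a 1.9-fold lower number from compound 1 to compound 4 (0.28 log units; within the scatter) stays within the scatter.

As far as these compounds go, whether an amine, a carboxylic acid or a longer chain at this place would match compound 4 remains open. Nothing available explains the difference that trifluoromethyl makes here.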